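Shrinking a ring on a quinoline-type core: compound 2 to 4

This account rests on a few compounds, and the source may have more. Where it says the series, first, only, none or still open, it means among the compounds named here.

Of the compounds shown here, three share a core and have been tested in a functional assay on HEK293 cells for activation of melanin-concentrating hormone receptor 1 (Homo sapiens), read by inositol phosphate accumulation; on this read-out lower numbers stand for an effect already at smaller amounts and higher numbers for an effect only at larger amounts of compound. Compound 1 `CCCc1cc(NC2CCC2)c2cc(NC(=O)/C=C/c3ccc(C(F)(F)F)cc3)ccc2n1` gives 270 nM; compound 2 `CCCc1cc(N2CCCC2)c2cc(NC(=O)/C=C/c3ccc(C(F)(F)F)cc3)ccc2n1` gives 2800 nM; compound 3 `CCCCc1ccc(/C=C/C(=O)Nc2ccc3nc(CCC)cc(N)c3c2)cc1` gives 740 nM. Compound 2 stands highest of the three, with compound 3 nearest and compound 1 furthest. For the measured compounds named here, the one measured step that touches this position, a 10-fold higher number from compound 1 to compound 2 (1.02 log units; beyond the scatter), shows that swapping the group there can move the result a long way. Compound 4 `CCCc1cc(N2CCC2)c2cc(NC(=O)/C=C/c3ccc(C(F)(F)F)cc3)ccc2n1` differs from compound 2 in one place: azetidin-1-yl in place of pyrrolidin-1-yl on an aromatic carbon. Going by the values given here, no measured step changes the size of a ring at this position, so the direction is uncertain; the fact that compound 1 and compound 3, carrying other groups there, both sit lower than compound 2 suggests a modest move toward lower numbers is more likely than a further rise. Compound 4 is therefore expected to give 1500 nM, within a range of 500 nM to 4500 nM, which means an expected step of a 1.9-fold lower number from compound 2 to compound 4 (0.27 log units; within the scatter).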

Compound 4, half-maximal effective concentration: 2500 nM
The estimate for compound 4 lay 1.7-fold (0.22 log units) below the measured number, and the stated range covers the measured number.
By their numbers in this assay, from the lowest: compound 1; then compound 3; then compounds 4 and 2 (each within the scatter of the next).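

In this assay putting azetidin-1-yl in place of pyrrolidin-1-yl gives a 1.1-fold lower number from compound 2 to compound 4 (0.05 log units; within the scatter) and so these two ring sizes cannot be told apart at this position. Azetidin-1-yl in place of cyclobutylamino gives a 9.3-fold higher number from compound 1 to compound 4 (0.97 log units; beyond the scatter) and this repeats what pyrrolidin-1-yl showed: among these three groups the lower number goes with cyclobutylamino, whose nitrogen lies outside its ring, and not with either ring size on the nitrogen. Nothing available explains why these groups sit where they do. 

On these data alone, it remains open whether a six-membered piperidin-1-yl or morpholin-4-yl would also sit with compound 2 and compound 4. As far as these compounds go, it is equally open whether the lower number of compound 1 would survive with cyclopropylamino, cyclopentylamino or an open-chain group such as propylamino in place of cyclobutylamino.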